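Reversing the Ester Arm on a Shared Amino Acid Core

The compounds below may be only part of what the source reports. "The series", "measured", "known", "first", "only" and "open" are said of these compounds alone.

Two compounds built on one core have been examined in a functional assay on IMR-32 cells for inhibition of Voltage-dependent N-type calcium channel subunit alpha-1B (Homo sapiens), read by calcium flux; a lower number here means a stronger inhibitor, a higher number a weaker inhibitor. Compound 1 `COc1ccc(COC(=O)[C@H](CC(=O)OC2CCCCCC2)NC(=O)OC(C)(C)C)cc1` gives 2600 nM. Compound 2 `CC(C)(C)OC(=O)N[C@@H](CC(=O)OC1CCCC1)C(=O)OCc1ccc(Cl)cc1` gives 3300 nM in this assay; the two numbers lie within the scatter of each other, so neither compound can be set apart from the other on these data. Compound 3 `COc1ccc(COC(=O)[C@H](COC(=O)C2CCCCC2)NC(=O)OC(C)(C)C)cc1` has not yet been measured. It differs from compound 1 by (cyclohexylcarbonyl)oxy in place of cycloheptyloxycarbonyl on a saturated chain carbon, two bonds along the chain from an amide-type nitrogen and a carbonyl carbon. Among the compounds with values here, no measured pair shows a change of this kind, so its size cannot be read from the compounds already in hand. Given that compound 1 gives 2600 nM and compound 2 gives 3300 nM, the expected step of a 1.3-fold higher number from compound 1 to compound 3 (0.13 log units; within the scatter) is a mild weakening at most, possibly none beyond the scatter. Compound 3 is therefore estimated at 3500 nM, within a range from 1200 nM to 10000 nM.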

Compound 3, half-maximal inhibitory concentration: 1600 nM
The estimate for compound 3 lay 2.2-fold (0.34 log units) above the measured number; the measured number falls inside the stated range.
By their numbers in this assay, from the lowest: compounds 3, 1 and 2 (each within the scatter of the next, the first and the last beyond it).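

Exchanging cycloheptyloxycarbonyl for (cyclohexylcarbonyl)oxy on a saturated chain carbon, two bonds along the chain from an amide-type nitrogen and a carbonyl carbon, gives a 1.6-fold lower number from compound 1 to compound 3 (0.21 log units; within the scatter) in this assay. Within the data shown here, this is the first reading at this position, and it shows that the ester arm can be reversed and its seven-membered ring exchanged for a six-membered one while compound 1 and compound 3 remain indistinguishable. No measurement available here accounts for this result.

Because the direction of the ester and the ring size differ together, the compounds shown do not separate the contribution of either. Going by these compounds, it also remains open how this assay would read with a primary amine, a carboxylic acid or a longer alkyl chain at this position.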